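This account rests on a few compounds, and the source may have more. Where it says the series, first, only, none or still open, it means among the compounds named here.

Measured compounds:
compound 1, `N#CCC1=C(C#N)CC(c2ccc(Br)cc2)=C(CC(=O)c2ccc(Br)cc2)O1`, 8200 nM
compound 2, `N#CCC1=C(C#N)CC(c2ccc([N+](=O)[O-])cc2)=C(CC(=O)c2ccc(Br)cc2)O1`, 2800 nM
compound 3, `N#CCC1=NN=C(c2ccc(Br)cc2)C(Br)O1`, 32000 nM

All three were tested in a functional assay on SF-268 cells (Homo sapiens) for inhibition, read by sulforhodamine B assay, with a stated time of 48 h; a higher number here means a weaker inhibitor of growth, a lower number a stronger inhibitor of growth. Compound 1 and compound 2 share one core and differ in a single place: nitro in place of bromo on an aromatic carbon. That change gave a 2.9-fold lower number from compound 1 to compound 2 (0.47 log units; beyond the scatter). Compound 3 is built on a different core; how the two cores differ is not broken down here. Compound 3 gives the highest of the three numbers, which makes it the weakest inhibitor of growth among them.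

Compound 4, `N#CCC1=NN=C(c2ccc([N+](=O)[O-])cc2)C(Br)O1`, is not yet measured. It differs from compound 3 by nitro in place of bromo on an aromatic carbon, the same change as that from compound 1 to compound 2, at a place described in the same words. For the measured compounds named here, the expectation for compound 4 rests on the one measured example of this change: a step of similar size, a 2.9-fold lower number from compound 3 to compound 4 (0.46 log units; beyond the scatter), is expected in this assay, because compound 1 to compound 2 gave a 2.9-fold lower number from compound 1 to compound 2 (0.47 log units; beyond the scatter). Going by the values given here, with only one example on a different core, the range is kept wide. Compound 4 is therefore estimated at 11000 nM, with a likely range from 4000 nM to 32000 nM.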

Compound 4, concentration for 50% growth inhibition: 6700 nM
Compound 4: the middle estimate sits 1.6-fold (0.22 log units) above what was measured, and the stated range covers the measured number.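

In this assay and with nitro in place of bromo on an aromatic carbon, the second core gave a 4.8-fold lower number from compound 3 to compound 4 (0.68 log units; beyond the scatter) and so moved the same way as the first. The sizes of the two steps also agree as closely as repeated measurements would allow: the same change on two cores in this assay, a 2.9-fold lower number (0.47 log units; beyond the scatter) from compound 1 to compound 2 and a 4.8-fold lower number (0.68 log units; beyond the scatter) from compound 3 to compound 4, 1.6-fold (0.21 log units) apart, within the scatter of two such steps. This shows that, for these two pairs, the change carried from one core to the other with its direction and approximate size intact, but two pairs cannot show that it would do so on every core in the series, and they do not reveal why the number falls.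

The compounds shown leave open how other groups at the same place, such as an amine or a carboxylic acid, would compare with nitro and bromo. They also leave open whether the same swap would give a similar step on a third core, or at a different place on these two cores.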